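A few compounds are considered here, and "the series" means these few. Any claim that something is new, unique, unknown or untested is made for them only; others in the source may bear on it.

For the measured compounds named here, compound 1 `COc1ccc(-c2cc(/C=C/C(=O)c3ccc(N)cc3)[nH]n2)cc1` gives 430 nM in a functional assay on MDA-MB-468 cells (Homo sapiens) for inhibition, read by sulforhodamine B assay, with a stated time of 48 h (a higher number here means a weaker inhibitor of growth, a lower number a stronger inhibitor of growth), the lower of the two numbers measured so far. Compound 2 `COc1cc(-c2cc(/C=C/C(=O)c3ccc(F)c(F)c3)[nH]n2)cc(OC)c1OC` gives 2220 nM in this assay, which lies beyond the scatter above the number for compound 1; as the two structures differ in several places, the pair shows no more than that. Compound 3 `COc1ccc(-c2cc(/C=C/C(=O)c3ccc(N)cc3)[nH]n2)cc1OC` differs from compound 1 by methoxy in place of hydrogen on an aromatic carbon. Going by the values given here, no single step of this kind has been measured. Compound 3 is expected to show only a modest rise in this assay, near the edge of the scatter, by a 1.5-fold higher number from compound 1 to compound 3 (0.18 log units; within the scatter). Compound 3 is accordingly estimated at 650 nM, within 250 nM to 1700 nM.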

Compound 3, concentration for 50% growth inhibition: 1550 nM
Beside the measured number, compound 3's estimate is 2.4-fold (0.38 log units) below it; measured number inside the range.
By their numbers in this assay, from the lowest: compound 1; then compounds 3 and 2 (each within the scatter of the next).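

Methoxy in place of hydrogen on an aromatic carbon, ortho to a methoxy group, gives a 3.6-fold higher number from compound 1 to compound 3 (0.56 log units; beyond the scatter) in this assay. For the compounds shown here, this is the first change in a single place, and it shows that this position is sensitive to substitution, with the added methoxy going with weaker growth inhibition. Nothing available accounts for this change. Going by these compounds, it remains open whether a smaller group such as fluorine or hydroxy at this position would be tolerated, or whether a longer chain such as ethoxy would weaken growth inhibition further.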